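The source may hold more compounds than are shown below. What is called first, only, known or untested is meant among the compounds shown, and "the series" means these compounds.

Measured so far in a functional assay on HCT-116 cells (Homo sapiens) for antiproliferative activity, read by MTT assay, with a stated time of 72 h; on this read-out lower numbers stand for stronger inhibition and higher numbers for weaker inhibition:
- Compound 1 `COc1ccccc1-c1cn(C[C@H](O)[C@H]2OC(=O)C(OCc3ccccc3)=C2OCc2ccccc2)nn1`: > 100000 nM, a limit
- Compound 2 `O=C1O[C@H]([C@@H](O)Cn2cc(CNS(=O)(=O)c3ccc(F)cc3)nn2)C(OCc2ccccc2)=C1OCc1ccccc1`: 22900 nM
- Compound 3 `Cc1ccc(-c2cn(C[C@H](O)[C@H]3OC(=O)C(OCc4ccccc4)=C3OCc3ccccc3)nn2)cc1`: > 100000 nM, a limit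

Compound 3 has only a limit and no number: it rests at the limit of > 100000 nM in this assay, at which 2 of the 3 values shown sit. Compound 4 `O=C1O[C@H]([C@@H](O)Cn2cc(CCO)nn2)C(OCc2ccccc2)=C1OCc1ccccc1` differs from it in one group: 2-hydroxyethyl in place of 4-methylphenyl on an aromatic carbon. In words, this is 2-hydroxyethyl in place of 4-methylphenyl on an aromatic carbon.

Two measured steps at that same carbon bear on the change. Putting (((4-fluorophenyl)sulfonyl)amino)methyl in place of 2-methoxyphenyl gave an at least 4.3-fold lower number from compound 1 to compound 2 (0.64 log units; beyond the scatter). Putting 4-methylphenyl in place of that same group gave an at least 4.3-fold higher number from compound 2 to compound 3 (0.64 log units; beyond the scatter). The remaining step, a step that the two limits leave unreadable from compound 1 to compound 3, cannot be sized. Among these three compounds, then, both phenyl-bearing groups sit at the limit and only compound 2 reaches a number, with no compound going against this. The 2-hydroxyethyl group, however, is neither of those groups, so these steps carry over only loosely.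

A modest move towards a lower number is therefore expected, and another result at the limit would be no surprise. The expected step is an at least 1.6-fold lower number from compound 3 to compound 4 (0.22 log units; that floor lies within the scatter). For compound 4 the estimated value is 60000 nM, with an expected range from 20000 nM to 100000 nM.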

Compound 4, half-maximal inhibitory concentration: 72700 nM
Compound 4: the middle estimate sits 1.2-fold (0.08 log units) below what was measured; the measured number falls inside the stated range.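

In this assay, compound 4 shows that the carbon of the five-membered aromatic ring can carry a small group with no ring, 2-hydroxyethyl, and still give a measured number, so a number here does not depend on the sulfonyl-bearing chain of compound 2. Even so, the change leaves only a floor that stays within the scatter, an at least 1.3-fold lower number from compound 3 to compound 4 (0.13 log units; that floor lies within the scatter), and the same holds for the replacement of 2-methoxyphenyl, an at least 1.3-fold lower number from compound 1 to compound 4 (0.13 log units; that floor lies within the scatter), so neither step shows a real gain over the phenyl-bearing groups. The one step beyond the scatter favours the sulfonyl-bearing chain, since hydroxymethyl in place of ((4-fluorophenyl)sulfonyl)amino gives a 3.2-fold higher number from compound 2 to compound 4 (0.50 log units; beyond the scatter), and among these four compounds no value goes against that order.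

How far compound 1 and compound 3 truly lie from compound 4 stays unknown, as both are limits and not numbers: the limit of > 100000 nM in this assay, at which 2 of the 4 values shown sit.

Also open, going by these compounds, is whether the hydroxyl of the 2-hydroxyethyl group matters at all, which a plain ethyl group, an amine or a carboxylic acid on the same chain, or a longer chain ending in hydroxyl could test.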